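Removing the aryl methyl in the pyrrolidine-diol series

The compounds below may be only part of what the source reports. "The series", "measured", "known", "first", "only" and "open" are said of these compounds alone.

Compound 1 `Cc1ccc([C@@H]2NC[C@H](O)[C@H]2O)cc1` is the reference point. In an assay on isolated protein for inhibition of alpha-mannosidase (Canavalia ensiformis), read by spectrophotometry, tested at 1000 uM (on this read-out lower numbers stand for less inhibition and higher numbers for more inhibition at the one concentration tested (going by the name of the read-out)), compound 1 gives 0.4%, the second highest of three numbers shown, and its neighbours sit close: compound 3 `O[C@@H]1[C@@H](O)CN[C@H]1c1ccc(-c2ccccc2)cc1` gives 0%, and compound 2 `O[C@H]1[C@H](O)CN[C@@H]1c1ccccc1` gives 8.3%, both within the scatter of compound 1, so no order among the three can be read.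

Compound 4 `O[C@@H]1[C@@H](O)CN[C@H]1c1ccccc1` has not yet been measured in this assay. It differs from compound 1 by hydrogen in place of methyl on an aromatic carbon. Going by the values given here, the only measured step at this position, a number 0.4 percentage points lower from compound 1 to compound 3 (within the scatter), stayed within the scatter, and nothing else among the measured compounds distinguishes the substituent at this carbon. Among the compounds with values here, every value so far lies near the bottom of the read-out. The expected step of a number 1.6 percentage points higher from compound 1 to compound 4 (within the scatter) is none beyond the scatter.

Compound 4 is therefore estimated at 2% in this assay, with a range from 0% to 12%.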

Compound 4, a percentage reported as inhibition, at one concentration (the size of the read-out at that concentration, not a potency): 2%
The estimate for compound 4 equals the measured number at the digits printed, and the stated range covers the measured number.
By their numbers in this assay, from the lowest: compounds 3, 1, 4 and 2 (each within the scatter of the next).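

Hydrogen in place of methyl on the aromatic carbon gives a number 1.6 percentage points higher from compound 1 to compound 4 (within the scatter), and hydrogen in place of phenyl at the same carbon gives a number 2 percentage points higher from compound 3 to compound 4 (within the scatter), so hydrogen, methyl and phenyl at this carbon cannot be told apart in this assay. Compound 4 also adds a mirror-image comparison, a number 6.3 percentage points lower from compound 2 to compound 4 (within the scatter), which shows that inverting all three stereocentres gives no step beyond the scatter in this pair. This comparison isolates configuration, with no change of substituent involved: the fact that compounds 2 and 4 differ only in the configuration as drawn

From the compounds shown here alone, all four numbers lie near the bottom of the read-out, so it remains open whether substituent or configuration would matter in compounds with greater inhibition. Going by these compounds, it also remains open whether an amine or a carboxylic acid at this aromatic carbon would give a step beyond the scatter.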